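The source may hold more compounds than are shown below. What is called first, only, known or untested is meant among the compounds shown, and "the series" means these compounds.

Three compounds have been measured in a functional assay on PC-3 cells (Homo sapiens) for inhibition, read by sulforhodamine B assay, with a stated time of 48 h; a higher number here means a weaker inhibitor of growth, a lower number a stronger inhibitor of growth:

Compound 1, `COc1ccc(-c2[nH]c3ccccc3c2/C=C(\C#N)S(=O)(=O)c2ccccc2)cc1`, gives 557 nM.
Compound 2, `COc1ccc(-c2[nH]c3ccc(OC)cc3c2/C=C(\C#N)S(=O)(=O)c2ccccc2)cc1`, gives 534 nM.
Compound 3, `CC(=O)/C(=C\c1c(-c2ccccc2)[nH]c2ccccc12)S(=O)(=O)c1ccccc1`, gives 2500 nM.

Compound 3 stands at the highest of these three numbers, so it is the weakest growth inhibitor of the set, and both compound 1 and compound 2 lie clearly lower. Compound 4, `O=C(/C(=C\c1c(-c2ccccc2)[nH]c2ccccc12)S(=O)(=O)c1ccccc1)c1ccccc1`, differs from compound 3 only by phenyl in place of methyl on a carbonyl carbon. Among the measured compounds shown here, the one measured step, a 1.0-fold lower number from compound 1 to compound 2 (0.02 log units; within the scatter), changes a different part of the molecule and says nothing about the carbonyl substituent, so no measured step bears on this change. With nothing to guide the direction, only a small step is expected, a 1.7-fold lower number from compound 3 to compound 4 (0.22 log units; within the scatter). Compound 4 is therefore estimated at 1500 nM, with a range from 400 nM to 6000 nM.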

Compound 4, concentration for 50% growth inhibition: 5000 nM
Beside the measured number, compound 4's estimate is 3.3-fold (0.52 log units) below it; low and high end bracket the measured number.
By their numbers in this assay, from the lowest: compounds 2 and 1 (each within the scatter of the next); then compounds 3 and 4 (each within the scatter of the next).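

In this assay, acetyl to benzoyl gives a 2.0-fold higher number from compound 3 to compound 4 (0.30 log units; within the scatter) and so stays within the scatter. Among the compounds shown here, this is the first measured change at the carbonyl substituent, and it shows that a whole six-membered aromatic ring can replace methyl on this carbonyl carbon without a change in growth inhibition that stands clear of the scatter. Nothing measured here offers an explanation for this result. From the compounds shown here alone, it remains open whether an amine, a carboxylic acid or a longer chain in this place would also stay within the scatter. Small rings other than phenyl, such as cyclopropyl, are equally unanswered.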